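The source may hold more compounds than are shown below. What is called first, only, known or untested is meant among the compounds shown, and "the series" means these compounds.

Measured compounds:
Compound 1 `Cc1ccc(-c2cn(-c3cc4ccc(O)c(C)c4oc3=O)nn2)cc1`, in a functional assay on MCF7 cells (Homo sapiens) for antiproliferative activity (a lower number here means a stronger inhibitor, a higher number a weaker inhibitor), compound 1 gives 23200 nM.
Compound 2 `Cc1c(O)ccc2cc(-n3cc(/C=C/c4ccccc4)nn3)c(=O)oc12`, compound 2 gives 33700 nM.
Compound 3 `CC(=O)Oc1ccc2cc(-n3cc(-c4c[nH]c5ccccc45)nn3)c(=O)oc2c1C`, compound 3 gives 7450 nM.

Compound 3 stands at the lowest of the three numbers in this assay; its gaps to compound 1 and to compound 2 both lie beyond the scatter, so it is the strongest inhibitor of the three measured. Within the data shown here, the only measured step, a 1.5-fold higher number from compound 1 to compound 2 (0.16 log units; within the scatter), concerns a different position of the shared core and lies within the scatter; it says nothing about the change now at hand.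

Compound 4 `Cc1c(O)ccc2cc(-n3cc(-c4c[nH]c5ccccc45)nn3)c(=O)oc12` differs from compound 3 by hydrogen in place of acetyl on an oxygen on an aromatic ring. Among the measured compounds shown here, no measured pair shows this exchange on this core: compounds 1 and 2 carry the hydroxy group, but they differ from compound 4 at another position as well, so their numbers do not isolate the change. With nothing to anchor a direction, no step beyond the scatter is expected from compound 3 to compound 4, and the uncertainty is kept wide.

Compound 4 is therefore estimated at 8500 nM, with a range from 3000 nM to 25000 nM. The step of a 1.1-fold higher number from compound 3 to compound 4 (0.06 log units; within the scatter) is the one this estimate expects.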

Compound 4, half-maximal inhibitory concentration: 8170 nM
Compound 4: the middle estimate sits 1.0-fold (0.02 log units) above what was measured; the range from low to high includes it.
By their numbers in this assay, from the lowest: compounds 3 and 4 (each within the scatter of the next); then compounds 1 and 2 (each within the scatter of the next).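

In this assay, replacing acetyl with hydrogen on the oxygen on the aromatic ring gives a 1.1-fold higher number from compound 3 to compound 4 (0.04 log units; within the scatter), so acetoxy and hydroxy cannot be told apart on this core. With the hydroxy group now shared, the group on the aromatic carbon can be compared on its own: 1H-indol-3-yl in place of 2-phenylethenyl gives a 4.1-fold lower number from compound 2 to compound 4 (0.62 log units; beyond the scatter), and 1H-indol-3-yl in place of 4-methylphenyl gives a 2.8-fold lower number from compound 1 to compound 4 (0.45 log units; beyond the scatter). Among these compounds, the steps beyond the scatter therefore come from the exchange on the aromatic carbon, not from the one on the oxygen.

Nothing available bears on the reason for these steps. From the compounds shown here alone, it remains open whether a methyl or a benzoyl group on that oxygen would also stay within the scatter, and how an amine or a carboxylic acid on the aromatic carbon would compare with 1H-indol-3-yl.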